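Methyl to phenyl near the ring oxygen, aortic potency

The source may report more compounds than this note shows. Statements on the series, on what has been measured and on what is new or still open speak of the compounds shown alone.

Compound 1 `Cc1ccc(S(=O)(=O)N(C)C(=O)NC(C)c2cc(Br)ccc2OCc2ccccc2)cc1` gives 67100 nM in a functional assay on thoracic aorta (Rattus norvegicus, strain Wistar), with a stated time of 15 min; a higher number here means that more compound is needed for the effect, a lower number that less compound is needed.
Compound 2 `CCOc1ccc(Br)cc1C(C)NC(=O)N(C)S(=O)(=O)c1ccc(C)cc1` gives 28600 nM in this assay.
Compound 3 `CCOc1ccc(Br)cc1C(C)NC(=O)NS(=O)(=O)c1ccccc1` gives > 300000 nM in this assay.

Compound 1 and compound 2 share one core and differ in a single spot: phenyl in place of methyl on a saturated chain carbon bound to an oxygen on an aromatic ring. That change produced a 2.3-fold higher number from compound 2 to compound 1 (0.37 log units; beyond the scatter), so compound 1 needs more material than compound 2 for the same effect. For compound 3 the measurement gave only a limit of the assay, not a number (the limit of > 300000 nM in this assay, at which 1 of the 3 values shown sits). How the core of compound 3 differs from the core of compound 2 is not broken down here.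

Compound 4 `CC(NC(=O)NS(=O)(=O)c1ccccc1)c1cc(Br)ccc1OCc1ccccc1` has not yet been measured in this assay. It stands to compound 3 exactly as compound 1 stands to compound 2: phenyl in place of methyl on a saturated chain carbon bound to an oxygen on an aromatic ring, the same change at the same place. The earlier step raised the number, and compound 3 already gave only a limit, so compound 4 is expected to lie beyond that limit as well. The expected step is a step that the limit leaves unreadable from compound 3 to compound 4, resting on the measured 2.3-fold higher number from compound 2 to compound 1 (0.37 log units; beyond the scatter). For compound 4 the estimate in this assay is 700000 nM, between 300000 nM and 3000000 nM, most probably again reported only as a limit.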

Compound 4, half-maximal effective concentration: 130000 nM
Compound 4: middle estimate off by 5.4-fold (0.73 log units), on the high side; measured number outside the range, below it.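

Putting phenyl in place of methyl on the core of compound 3 gave an at least 2.3-fold lower number from compound 3 to compound 4 (0.36 log units; beyond the scatter) in this assay, which runs opposite to the step seen on the other core. The change therefore cannot simply be carried from one core to the other in this series, as its effect differs in direction: the same change on two cores in this assay, a 2.3-fold higher number (0.37 log units; beyond the scatter) from compound 2 to compound 1 and an at least 2.3-fold lower number (0.36 log units; beyond the scatter) from compound 3 to compound 4, at least 5.4-fold (0.73 log units) apart, beyond the scatter of two such steps

From the compounds shown here alone, compound 3 gave only a limit of the assay, > 300000 nM, so the true size of its step stays unknown, and these two pairs do not show what in the cores makes the results part ways.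

No single change connects the two cores among the compounds shown, so it remains open which part of the core decides the direction of the step. Also open, going by these compounds, is how a longer chain or an amine would behave at this place on either core.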